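The compounds below may be only part of what the source reports. "The series", "measured", "known", "first", "only" and "open" are said of these compounds alone.

Of the compounds shown here, three have so far been tested in a functional assay on HCT-116 cells (Homo sapiens) for antiproliferative activity, read by MTT assay, with a stated time of 72 h; on this read-out higher numbers stand for weaker inhibition and lower numbers for stronger inhibition. There compound 1 (`Oc1ccc(Cl)cc1/C=N/c1ccc(-c2nc3ccccc3o2)c(O)c1`) gives 20100 nM and compound 3 (`O=C(CSc1cccc(O)c1)Nc1ccc2nc(NC(=O)c3cccs3)sc2c1`) gives 7020 nM in the same read-out. Compound 2 (`Cc1ccc(SCC(=O)Nc2ccc3nc(NC(=O)c4ccc(C(F)(F)F)cc4)sc3c2)c(C)c1`) gives 320 nM and so holds the lowest number of the three, the strongest inhibition in this small set, with its gap to each of the other two beyond the usual scatter. Compound 4 (`O=C(CSC1CCCCC1)Nc1ccc2nc(NC(=O)c3ccc(C(F)(F)F)cc3)sc2c1`) has not yet been measured. It matches compound 2 except for one group, with cyclohexyl in place of 2,4-dimethylphenyl on a sulfur. The ring on that sulfur thus changes from aromatic to non-aromatic. Among the measured compounds shown here, no pair of measured compounds shows this exchange or any other single change, so the data give no direct guide to its effect. The expectation therefore rests on compound 2 at 320 nM being the lowest number seen so far, which leaves a return toward higher numbers as the likelier direction. A small move toward weaker inhibition is expected, with the estimated 2.2-fold higher number from compound 2 to compound 4 (0.34 log units; beyond the scatter) lying not far past the scatter. For compound 4 the estimate is 700 nM with an expected range from 150 nM to 3000 nM in this measurement.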

Compound 4, half-maximal inhibitory concentration: 21000 nM
For compound 4 the middle estimate is 30-fold (1.48 log units) below the measured one; measured number outside the range, above it.
By their numbers in this assay, from the lowest: compound 2; then compound 3; then compounds 1 and 4 (each within the scatter of the next).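

In this assay, among the compounds shown here, the exchange of 2,4-dimethylphenyl for cyclohexyl on a sulfur gives the first single-change step in this set, a 66-fold higher number from compound 2 to compound 4 (1.82 log units; beyond the scatter), and that step is large. It shows that this position is far from indifferent: with the rest of the molecule unchanged, the group on the sulfur alone separates the strongest inhibition seen here from a much weaker result, so keeping the shared core does not by itself hold the number low, and a six-membered carbon ring of any kind does not serve equally well at this place. Nothing measured on these compounds offers an explanation for the size of the step.

The compounds shown leave open which part of the change carries the step, as the exchange removes the aromatic character of the ring and the two methyl groups of the 2,4-dimethylphenyl together. Going by these compounds, how an unsubstituted phenyl, a 4-methylphenyl or a pyridyl ring on that sulfur would read also remains open, and any of these would help to separate those two parts.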